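Adding a long chain to compound 3

The source may report more compounds than this note shows. Statements on the series, on what has been measured and on what is new or still open speak of the compounds shown alone.

- compound 1 `COC(=O)CCc1ccc(S(=O)(=O)n2c(C3(O)C=CC(=O)C=C3)cc3ccccc32)cc1` gives 280 nM 
- compound 2 `O=C1C=CC(O)(c2cc3ccccc3n2S(=O)(=O)c2ccc(CCCO)cc2)C=C1` gives 51 nM 
- compound 3 `O=C1C=CC(O)(c2cc3ccccc3n2S(=O)(=O)c2ccc(CCC(=O)O)cc2)C=C1` gives 3300 nM 

In an ADME assay on MRC5 cells (Homo sapiens) for cytotoxicity, read by fluorescence and resazurin assay, with a stated time of 3 days (a lower number here means that less compound is needed, a higher number that more compound is needed for the effect), compound 3 stands highest of the three, at 3300 nM, so it needs the most compound for the effect. Compound 4 `Nc1nc(N)nc(NCCCOC(=O)CCc2ccc(S(=O)(=O)n3c(C4(O)C=CC(=O)C=C4)cc4ccccc43)cc2)n1` differs from it in one place (3-((4,6-diamino-1,3,5-triazin-2-yl)amino)propyl in place of hydrogen on an oxygen next to a carbonyl group). The nearest guide is compound 1, which holds a methyl on that same oxygen. Hydrogen in place of that methyl gave a 12-fold higher number from compound 1 to compound 3 (1.07 log units; beyond the scatter), a large step. Undoing this should therefore bring a large step to a lower number in this assay, although no measured compound carries so big a group there. The estimate is an expected 11-fold lower number from compound 3 to compound 4 (1.04 log units; beyond the scatter). Compound 4 is estimated at 300 nM, with an expected range of 70 nM to 1300 nM in this assay.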

Compound 4, half-maximal effective concentration: 950 nM
Compound 4: middle estimate off by 3.2-fold (0.50 log units), on the low side; low and high end bracket the measured number.
By their numbers in this assay, from the lowest: compound 2; then compound 1; then compound 4; then compound 3.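

On this oxygen next to a carbonyl group, the 3-((4,6-diamino-1,3,5-triazin-2-yl)amino)propyl group with its 12 heavy atoms still gives, in this assay, a 3.5-fold lower number from compound 3 to compound 4 (0.54 log units; beyond the scatter) when it replaces hydrogen. Against methyl on the same oxygen, the picture is a 3.4-fold higher number from compound 1 to compound 4 (0.53 log units; beyond the scatter) so the large group lands between hydrogen and methyl, and the gain from methyl carries over only in part. Nothing shown here explains these steps.

As far as these compounds go, whether a plain propyl group, or a propyl chain ending in an amine, would land closer to compound 1 stays open.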